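This account rests on a few compounds, and the source may have more. Where it says the series, first, only, none or still open, it means among the compounds named here.

Among the measured compounds shown here, only one compound in this small series has a number so far. In a functional assay on PC-3 cells (Homo sapiens) for antiproliferative activity, read by CCK-8 assay, with a stated time of 6 days (a higher number here means a weaker inhibitor, a lower number a stronger inhibitor), compound 1 (`CCN(c1ccc(C#N)c(Cl)c1)c1cc(-c2ccncc2)ccc1C`) gives 3580 nM as its result. In this assay compound 2 (`CCN(c1cccc(-c2ccccc2)c1)c1ccc(C#N)c(Cl)c1`) stands at "not determined" (no result reported) and compound 3 (`CCN(c1ccc(C#N)c(Cl)c1)c1cc(-c2ccccc2)ccc1C`) stands at "not determined" (no result reported) as well. Compound 3 therefore has no place on the scale, and any comparison with it must wait for a real number.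

The next compound to be tested is compound 4 (`CCN(c1ccc(C#N)c(Cl)c1)c1cc(-c2c[nH]nc2C)ccc1C`). It carries 3-methyl-1H-pyrazol-4-yl in place of phenyl on an aromatic carbon. The swap keeps the size of the group but changes the ring and what it holds.

For the measured compounds named here, no measured step shows what such a change does. The expectation in this assay is therefore for no shift beyond the usual scatter, with compound 1 at 3580 nM as the only anchor. For compound 4 the estimated value is 3000 nM with an expected range from 800 nM to 12000 nM for now.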

Compound 4, half-maximal inhibitory concentration: 9030 nM
Compound 4: middle estimate off by 3.0-fold (0.48 log units), on the low side, within the range that was stated.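

Putting 3-methyl-1H-pyrazol-4-yl in place of pyridin-4-yl gives a 2.5-fold higher number from compound 1 to compound 4 (0.40 log units; beyond the scatter) in this assay, so compound 4 is the weaker inhibitor of the pair, though the step is modest. This first measured step shows that the result responds to which ring sits on this aromatic carbon, para to a methyl group, while the comparison with the phenyl of compound 3 cannot be read without a number for compound 3. No independent evidence here accounts for the shift.

The compounds shown do not separate the contribution of the five-membered ring from that of its methyl group, so the plain 1H-pyrazol-4-yl ring would be the informative comparison. As far as these compounds go, how a pyridin-3-yl ring, or a pyridin-4-yl ring carrying an amine, would behave at this position also remains open.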